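This account rests on a few compounds, and the source may have more. Where it says the series, first, only, none or still open, it means among the compounds named here.

Compound 2 `COc1cc(-c2nn(-c3cccc(NC(=O)Nc4ccc(Cl)c(C(F)(F)F)c4)c3)cc2-c2ccncc2)ccc1Cl` gives 985 nM in a functional assay on U-251 cells (Homo sapiens) for inhibition, read by sulforhodamine B assay, with a stated time of 48 h (on this read-out higher numbers stand for weaker inhibition of growth and lower numbers for stronger inhibition of growth), the highest of the two numbers recorded, with compound 1 `COc1cc(-c2nn(-c3cccc(NC(=O)Nc4ccc(Cl)c(Cl)c4)c3)cc2-c2ccncc2)ccc1Cl` at 820 nM differing only within the scatter. Compound 3 `COc1cc(-c2nn(-c3cccc(NC(=O)c4ccccc4)c3)cc2-c2ccncc2)ccc1Cl` is not yet measured; it differs from compound 2 by phenyl in place of (4-chloro-3-(trifluoromethyl)phenyl)amino on a carbonyl carbon. Going by the values given here, the one measured step, a 1.2-fold higher number from compound 1 to compound 2 (0.08 log units; within the scatter), swaps substituents on the outer ring and does not remove the arylamino group, so it bears only loosely on this change. With no direct guide, compound 3 is expected to show weaker growth inhibition, a step of a 3.6-fold higher number from compound 2 to compound 3 (0.55 log units; beyond the scatter). Compound 3 is estimated at 3500 nM, within 800 nM to 15000 nM.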

Compound 3, concentration for 50% growth inhibition: 661 nM
The estimate for compound 3 lay 5.3-fold (0.72 log units) above the measured number; the whole stated range lies above it.
By their numbers in this assay, from the lowest: compounds 3, 1 and 2 (each within the scatter of the next).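

In this assay, putting phenyl on the carbonyl carbon in place of either arylamino group leaves the number within the scatter (a 1.5-fold lower number from compound 2 to compound 3 (0.17 log units; within the scatter)) and (a 1.2-fold lower number from compound 1 to compound 3 (0.09 log units; within the scatter)). For these three compounds, this position therefore accepts the loss of the whole substituted arylamino group, including the amide hydrogen it carries, with no readable change in growth inhibition. No supporting measurement is available to explain this. On these data alone, whether a smaller group such as methyl, an amine or a carboxylic acid on this carbonyl carbon would give a similar number remains open. So does whether substituents on the entering phenyl would matter.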